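The source may hold more compounds than are shown below. What is called first, only, known or untested is meant among the compounds shown, and "the series" means these compounds.

Three compounds of a shared core stand on record in an assay on isolated protein for inhibition of Dihydrofolate reductase (Mus musculus); on this read-out lower numbers stand for lower potency and higher numbers for higher potency (the scale is a negative logarithm). Compound 1 `CC1(C)N=C(N)N=C(N)N1c1cccc(CNC(=O)Nc2cccc(C#N)c2)c1` gives 8.19 in this assay. Compound 2 `CC1(C)N=C(N)N=C(N)N1c1ccc(OCCCCNC(=O)Nc2cccc(S(=O)(=O)F)c2)c(Cl)c1` gives 7.7, and compound 3 `CC1(C)N=C(N)N=C(N)N1c1cccc(CCCCc2cc(Cl)ccc2S(=O)(=O)F)c1` gives 7.96. Of the three numbers, compound 1 holds the highest; the value of compound 3 sits within the usual scatter of it, whereas the value of compound 2 lies beyond the scatter below it.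

The account now follows a single change made on compound 1 to reach compound 4 `CC1(C)N=C(N)N=C(N)N1c1cccc(CNC(=O)Nc2cccc([N+](=O)[O-])c2)c1`, which has not yet been measured in this assay. The change is nitro in place of cyano on an aromatic carbon: one group on an aromatic carbon of a six-membered aromatic ring of carbon only, meta to a large group, is exchanged for another, and the rest of the molecule is untouched.

Within the data shown here, no pair of measured compounds shows this exchange, so its effect has to be estimated. The step is expected to be small, at a number 0.09 log units lower from compound 1 to compound 4 (within the scatter), with no clear direction beyond the scatter. Compound 4 is therefore estimated at 8.1, in a range from 7.6 to 8.6.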

Compound 4, logarithm of the reciprocal of the active concentration, log(1/C): 8.1
Estimate against measurement, compound 4: no gap at the digits printed; measured number inside the range.
By their numbers in this assay, from the lowest: compounds 2, 3, 4 and 1 (each within the scatter of the next, the first and the last beyond it).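

In this assay, among these compounds, the exchange gives a number 0.09 log units lower from compound 1 to compound 4 (within the scatter), the first step in this set between two compounds that differ in one place. At this aromatic carbon, meta to a large group, the 3-cyanophenyl and 3-nitrophenyl compounds therefore cannot be told apart, even though nitro enters with more heavy atoms and hydrogen-bond acceptors than the cyano it replaces. Nothing measured here beyond these potency numbers bears on the result.

The compounds shown leave open whether an amine or a carboxylic acid on this same carbon would also stay within the scatter of compound 1. They also leave open whether the nitro-for-cyano exchange would read the same way on a compound with a longer chain.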